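The compounds below may be only part of what the source reports. "The series", "measured", "known", "first", "only" and "open" are said of these compounds alone.

Three compounds share one core and differ only in the group carried on the six-membered ring. Compound 1 `Sc1nnc(-c2cccc(Cl)c2)o1` carries chloro and in an assay (Populus sieboldii x Populus grandidentata) for inhibition of Trans-cinnamate 4-monooxygenase (Populus kitakamiensis), with a stated time of 60 min (a higher number here means a weaker inhibitor, a lower number a stronger inhibitor), compound 1 gives 210 nM. Compound 2 `Cc1cccc(-c2nnc(S)o2)c1` carries methyl, and in this assay compound 2 gives 1100 nM. Compound 3 `Fc1cccc(-c2nnc(S)o2)c1` carries fluoro, and in this assay compound 3 gives 130 nM, the lowest of the three numbers; the step of a 1.6-fold lower number from compound 1 to compound 3 (0.21 log units; within the scatter) lies within the scatter, while the step of an 8.5-fold lower number from compound 2 to compound 3 (0.93 log units; beyond the scatter) is clear.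

Compound 4 `COc1cccc(-c2nnc(S)o2)c1` is the next member, not yet measured. The change from compound 3 is methoxy in place of fluoro on an aromatic carbon. Among the measured compounds shown here, the steps that bear on this are a 1.6-fold lower number from compound 1 to compound 3 (0.21 log units; within the scatter) and an 8.5-fold lower number from compound 2 to compound 3 (0.93 log units; beyond the scatter); together they show that a small halogen is tolerated, while a larger carbon group raised the number. Methoxy, like methyl, is a larger group, so compound 4 is expected to show a moderately higher number, a step of a 3.8-fold higher number from compound 3 to compound 4 (0.59 log units; beyond the scatter). For compound 4 the estimate in this assay is 500 nM, with a range from 150 nM to 1700 nM.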

Compound 4, half-maximal inhibitory concentration: 6100 nM
Compound 4: the middle estimate sits 12-fold (1.09 log units) below what was measured; measured number above the stated range.
By their numbers in this assay, from the lowest: compounds 3 and 1 (each within the scatter of the next); then compound 2; then compound 4.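

In this assay, among the compounds shown here, this position on the six-membered ring proves far more sensitive than the earlier compounds showed: methoxy in place of fluoro gives a 47-fold higher number from compound 3 to compound 4 (1.67 log units; beyond the scatter), and methoxy in place of chloro gives a 29-fold higher number from compound 1 to compound 4 (1.46 log units; beyond the scatter). Methoxy also differs clearly from methyl, with a 5.5-fold higher number from compound 2 to compound 4 (0.74 log units; beyond the scatter), so adding an oxygen to the methyl group pushes the number further in the same direction, and methoxy is the least tolerated of the four groups shown. Nothing available explains this loss of inhibition.

The compounds shown do not separate the effect of the oxygen from that of the larger group, a question that ethyl, with two carbons and no oxygen, or hydroxy could help address. On these data alone, how an amine or a carboxylic acid would fare at this position also remains open.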